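Replacing the 2,4-dihydroxyphenyl group of compound 3

A few compounds are considered here, and "the series" means these few. Any claim that something is new, unique, unknown or untested is made for them only; others in the source may bear on it.

In a toxicity assay on cells (Fibroblast, Homo sapiens) for cytotoxicity; on this read-out higher numbers stand for weaker inhibition and lower numbers for stronger inhibition:
Compound 1 `CC(/C=C/C1=CCCCC1(C)C)=C\C=C\C(C)=C\COC(=O)c1cc(O)ccc1O`: 14000 nM
Compound 2 `COc1cccc(C(=O)OC/C=C(C)/C=C/C=C(C)/C=C/C2=CCCCC2(C)C)c1O`: 27000 nM
Compound 3 `CC(/C=C/C1=CCCCC1(C)C)=C\C=C\C(C)=C\COC(=O)c1ccc(O)cc1O`: 120000 nM

Compound 3 has the highest number of the three, and so the weakest inhibition. Compound 4 `CC(=O)Oc1ccccc1C(=O)OC/C=C(C)/C=C/C=C(C)/C=C/C1=CCCCC1(C)C` keeps the shared core but has 2-acetoxyphenyl in place of 2,4-dihydroxyphenyl on a carbonyl carbon. Among the compounds with values here, no measured step makes this exact change. The closest evidence is a 4.4-fold higher number from compound 2 to compound 3 (0.65 log units; beyond the scatter) and an 8.6-fold higher number from compound 1 to compound 3 (0.93 log units; beyond the scatter), both beyond the scatter, whereas a 1.9-fold higher number from compound 1 to compound 2 (0.29 log units; within the scatter) lies within it. With only these compounds as a guide, a moderately lower number is expected in this assay. The expected size is a 3.0-fold lower number from compound 3 to compound 4 (0.48 log units; beyond the scatter). Compound 4 is estimated at 40000 nM, with an expected range from 12000 nM to 130000 nM.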

Compound 4, half-maximal inhibitory concentration: 150000 nM
The estimate for compound 4 lay 3.8-fold (0.57 log units) below the measured number; measured number outside the range, above it.
By their numbers in this assay, from the lowest: compounds 1 and 2 (each within the scatter of the next); then compounds 3 and 4 (each within the scatter of the next).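

In this assay, 2-acetoxyphenyl, with 0 hydrogen-bond donors, gives a 1.3-fold higher number from compound 3 to compound 4 (0.10 log units; within the scatter), so it cannot be told apart from 2,4-dihydroxyphenyl, which has 2. Against the other two groups on this carbonyl carbon, the change is clear, with a 5.6-fold higher number from compound 2 to compound 4 (0.74 log units; beyond the scatter) and an 11-fold higher number from compound 1 to compound 4 (1.03 log units; beyond the scatter), so the two dihydroxyphenyl groups differ from each other more than 2-acetoxyphenyl differs from 2,4-dihydroxyphenyl. Nothing available explains these differences. The compounds shown leave open how an aminophenyl group, or a phenyl group carrying a carboxylic acid, would behave on this carbonyl carbon.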